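This account rests on a few compounds, and the source may have more. Where it says the series, first, only, none or still open, it means among the compounds named here.

Among the compounds with values here, compound 1 `Nc1nc(-c2ccc(C3CC3)o2)nc2sc(Cc3ccccc3)cc12` is the only one of the three compounds whose reading in a functional assay on CHO-K1 cells for antagonist activity at adenosine receptor A1 (Homo sapiens), read by a beta-galactosidase reporter and cAMP accumulation, with stated times of 15 min and 6 h (on this read-out higher numbers stand for weaker inhibition and lower numbers for stronger inhibition), is a plain number: in this assay compound 1 gives 861 nM. Compound 2 `N#Cc1cccc(-c2nc(N)c3cc(Cc4ccccc4F)sc3n2)c1` returns only a limit of this assay, at < 16 nM. Compound 3 `C=C(c1ccccc1)c1cc2c(N)nc(-c3cccc(C#N)c3)nc2s1` likewise returns a limit, at > 1000 nM. Within the data shown here, the single one-point step available, an at least 62-fold higher number from compound 2 to compound 3 (1.79 log units; beyond the scatter), concerns a different position on the shared core and shows only that a change there can move the number strongly. Compound 4 `Nc1nc(-c2ccncc2)nc2sc(Cc3ccccc3)cc12` differs from compound 1 by pyridin-4-yl in place of 5-cyclopropylfuran-2-yl on an aromatic carbon. Among the measured compounds shown here, no measured step touches that position, so the direction is open. Compound 4 is therefore estimated at 450 nM, within 80 nM to 2500 nM, which is expected to amount to a 1.9-fold lower number from compound 1 to compound 4 (0.28 log units; within the scatter).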

Compound 4, inhibition constant: 812 nM
Compound 4: middle estimate off by 1.8-fold (0.26 log units), on the low side; low and high end bracket the measured number.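

Placed on the aromatic carbon between two ring nitrogen atoms, pyridin-4-yl in place of 5-cyclopropylfuran-2-yl gives in this assay a 1.1-fold lower number from compound 1 to compound 4 (0.03 log units; within the scatter). This first reading at this position shows that, for this pair, a six-membered aromatic ring and a five-membered aromatic ring carrying a three-membered ring cannot be told apart. Nothing at hand bears on why these two groups read alike.

On these data alone, whether a carboxylic acid, an amine or a longer chain at this carbon would leave the number in the same range stays open. So does whether this exchange would read alike with another group on the shared core.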